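A few compounds are considered here, and "the series" means these few. Any claim that something is new, unique, unknown or untested is made for them only; others in the source may bear on it.

Of the compounds shown here, three that share one core have been measured in a functional assay on MGC-803 cells (Homo sapiens) for antiproliferative activity, read by CCK-8 assay, with a stated time of 72 h, tested at 8 uM; a higher number here means a stronger effect of the compound at the concentration tested, a lower number a weaker effect. Compound 2 `CC1CCCCN1C(=S)SCc1ccc(C(=O)Nc2ccccc2N)cc1` stands highest: in this assay compound 2 gives 86.9%. Compound 1 `Nc1ccccc1NC(=O)c1ccc(CSC(=S)N2CCc3cc([N+](=O)[O-])ccc32)cc1` gives 33.2% in this assay, and compound 3 `Nc1ccccc1NC(=O)c1ccc(CSC(=S)N2CCN(Cc3ccccc3)CC2)cc1` gives 19.7%, both of them well beyond the scatter below compound 2. Compound 4 `CN(C(=S)SCc1ccc(C(=O)Nc2ccccc2N)cc1)c1cccnc1` has not yet been measured. It differs from compound 2 in one place, (methyl(pyridin-3-yl)amino in place of 2-methylpiperidin-1-yl on a thiocarbonyl carbon). Among the compounds with values here, no step between measured compounds matches this change, so the expectation rests only on the three numbers above, where the group on the thiocarbonyl carbon is the part that varies. A decrease beyond the scatter is expected, a number 36.9 percentage points lower from compound 2 to compound 4 (beyond the scatter). For compound 4 the estimated inhibition in this assay is 50%, within a range from 20% to 80%.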

Compound 4, a percentage reported as inhibition, at one concentration (the size of the read-out at that concentration, not a potency): 82.5%
Compound 4: the middle estimate sits 32.5 percentage points below what was measured; the whole stated range lies below it.
By their numbers in this assay, from the lowest: compound 3; then compound 1; then compounds 4 and 2 (each within the scatter of the next).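

In this assay, placing methyl(pyridin-3-yl)amino on the thiocarbonyl carbon instead of 2-methylpiperidin-1-yl gives a number 4.4 percentage points lower from compound 2 to compound 4 (within the scatter). At this position, then, a six-membered aromatic ring can stand in for a six-membered non-aromatic ring with the read-out at this concentration preserved. Nothing measured here explains why these two groups read alike.

Going by these compounds, whether the ring nitrogen of the pyridine matters remains open, and methyl(phenyl)amino on the same carbon would test that. A smaller group such as dimethylamino would show whether a ring is needed here at all.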